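The source may report more compounds than this note shows. Statements on the series, on what has been measured and on what is new or still open speak of the compounds shown alone.

- Compound 1 `CC1=CC[C@@H]([C@@](C)(O)CCCC(C)(C)NC(=S)N/N=C\c2ccc(C)cc2)CC1`: 30500 nM
- Compound 2 `COc1ccc(/C=N\NC(=S)NC(C)(C)CCC[C@](C)(O)[C@@H]2CC=C(C)CC2)cc1`: 57000 nM
- Compound 3 `CC1=CC[C@@H]([C@@](C)(O)CCCC(C)(C)NC(=S)N/N=C\c2ccccc2[N+](=O)[O-])CC1`: > 100000 nM (a limit)

In a functional assay on NCI/ADR cells (Homo sapiens) for cytotoxicity, read by sulforhodamine B assay (a lower number here means a stronger inhibitor of growth, a higher number a weaker inhibitor of growth), compound 2 gives 57000 nM, and it cannot be told apart from compound 1: the step is a 1.9-fold higher number from compound 1 to compound 2 (0.27 log units; within the scatter). The value of compound 3 is a limit of the assay, not a number.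

Compound 4 `CC1=CC[C@@H]([C@@](C)(O)CCCC(C)(C)NC(=S)N/N=C\c2ccc([N+](=O)[O-])cc2)CC1` carries nitro in place of methoxy on an aromatic carbon, para to a large group (nitro in place of methoxy on an aromatic carbon).

The nearest measured change is 2-nitrophenyl in place of 4-methoxyphenyl, an at least 1.7-fold higher number from compound 2 to compound 3 (0.24 log units; that floor lies within the scatter). Its companion from compound 1 is an at least 3.2-fold higher number from compound 1 to compound 3 (0.51 log units; beyond the scatter). Both point upward, so a small rise in this assay is expected, possibly within the scatter and possibly reaching the limit. The expected step is a 1.3-fold higher number from compound 2 to compound 4 (0.12 log units; within the scatter). For compound 4 the estimate is 75000 nM, with an expected range of 35000 nM to 100000 nM.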

Compound 4, concentration for total growth inhibition: > 100000 nM
Compound 4: only a limit was reported; the forecaster's own chance of this, stated with the estimate: 40%; at least 1.3-fold (0.12 log units) between middle value and limit.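

In this assay the value of compound 4 is a limit, not a number, and with 4-nitrophenyl as with 2-nitrophenyl no readable value appears, so the step between compound 3 and compound 4 cannot be read: the limit of > 100000 nM in this assay, at which 2 of the 4 values shown sit.

Nitro in place of methyl gives an at least 3.2-fold higher number from compound 1 to compound 4 (0.51 log units; beyond the scatter). Nitro in place of methoxy gives an at least 1.7-fold higher number from compound 2 to compound 4 (0.24 log units; that floor lies within the scatter), so this change alone does not separate compound 2 from compound 4.

From the compounds shown here alone, how far past the limit compound 3 and compound 4 lie stays open. So does whether an amine or a carboxylic acid on this aromatic carbon would give a readable value.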